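This account rests on a few compounds, and the source may have more. Where it says the series, first, only, none or still open, it means among the compounds named here.

Within the data shown here, in an assay for inhibition of alpha-N-acetylgalactosaminidase (Gallus gallus), tested at 1000 uM (on this read-out higher numbers stand for more inhibition at the one concentration tested (going by the name of the read-out) and lower numbers for less inhibition), compound 1 `O=C(O)[C@H]1NC[C@H](O)[C@@H](O)[C@H]1O` gives 31%, while compound 2 `O=C(O)[C@@H]1NC[C@H](O)[C@@H](O)[C@H]1O` gives 4%, the lower of the two numbers so far. Among the measured compounds shown here, the one measured step, a number 27 percentage points lower from compound 1 to compound 2 (beyond the scatter), rests on (the fact that compounds 1 and 2 differ only in the configuration as drawn). Compound 3 `O=C(O)[C@@H]1NC[C@@H](O)[C@H](O)[C@H]1O` differs from compound 2 in the following way: the two compounds have the same atoms and bonds and differ only in configuration as drawn: 2 of 4 stereo elements differ; a stereocentre at a saturated ring carbon is drawn S in compound 2 and R in compound 3; a stereocentre at a saturated ring carbon is drawn R in compound 2 and S in compound 3. That single measured step shows a configuration change alone moving the read-out by a modest amount, so a shift of similar size in either direction is plausible here, with the starting point already near the floor. For compound 3 the expected step is a number 6 percentage points higher from compound 2 to compound 3 (within the scatter). Compound 3 is estimated at 10%, with a range from 0% to 35%.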

Compound 3, a percentage reported as inhibition, at one concentration (the size of the read-out at that concentration, not a potency): 1.3%
The estimate for compound 3 lay 8.7 percentage points above the measured number; the range from low to high includes it.
By their numbers in this assay, from the lowest: compounds 3 and 2 (each within the scatter of the next); then compound 1.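

In this assay, two more stereocentre changes on top of compound 2 give a number 2.7 percentage points lower from compound 2 to compound 3 (within the scatter), so they add no readable shift. Among these compounds, with three of the four stereo elements changed, the step is a number 29.7 percentage points lower from compound 1 to compound 3 (beyond the scatter), and compound 1 remains the only compound set apart from both others. Configuration alone accounts for that separation: the fact that compounds 1 and 3 differ only in the configuration as drawn

Still open, from the compounds shown here alone, is how a hydroxymethyl or amide group in place of the carboxylic acid would read on the core of compound 1. Also open, going by these compounds, is what the fourth stereocentre alone would do.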